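Benzyl for Oxopyrrolidinyl on a Non-Toxic Amide Scaffold

The source may report more compounds than this note shows. Statements on the series, on what has been measured and on what is new or still open speak of the compounds shown alone.

Compound 1 `O=C(Nc1cccc(N2CCCC2=O)c1)C1CCCN(C(=O)c2cc(C(F)(F)F)cc(C(F)(F)F)c2)C1` was tested in an ADME assay on PC-3 cells (Homo sapiens) for cytotoxicity, read by WST assay, tested at 100 uM (a lower number here means less inhibition, a higher number more inhibition at the concentration tested (going by the name of the read-out)), where compound 1 gives 0%. A second member of the same series, compound 2 `CSc1cccc(C(=O)N2CCCC(C(=O)Nc3ccc(Cl)cc3)C2)c1`, stands level with it: in this assay compound 2 gives 0%, and the two values lie within the scatter of each other, so no order between them can be drawn. Compound 1 therefore sits at the floor of what this read-out can report, and nothing in the measured pair points to a cytotoxic signal at the concentration tested.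

The next compound, compound 3 `O=C(Nc1cccc(Cc2ccccc2)c1)C1CCCN(C(=O)c2cc(C(F)(F)F)cc(C(F)(F)F)c2)C1`, differs from compound 1 in a single place: benzyl in place of 2-oxopyrrolidin-1-yl on an aromatic carbon. Among the measured compounds shown here, no measured pair shows a step of this kind, so the size of its effect in this assay is not known from the data at hand. Compound 1 gives 0% and compound 2 gives 0%, both at the bottom of the scale. On that basis the step is expected to be none beyond the scatter, a number 5 percentage points higher from compound 1 to compound 3 (within the scatter). Compound 3 is thus estimated at 5% in this assay, with a range from 0% to 25%.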

Compound 3, a percentage reported as inhibition, at one concentration (the size of the read-out at that concentration, not a potency): 0%
The estimate for compound 3 lay 5 percentage points above the measured number; the measured number falls inside the stated range.
By their numbers in this assay, from the lowest: compounds 1, 2 and 3 (each within the scatter of the next).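

Among the compounds shown here, the exchange of 2-oxopyrrolidin-1-yl for benzyl on this aromatic carbon, meta to a large group, comes in this assay to no change at the digits printed from compound 1 to compound 3 (within the scatter), which is the first reading of a change made in one place. The group that leaves holds a carbonyl and a hydrogen-bond acceptor in a five-membered non-aromatic ring, while the group that enters has no hydrogen-bond acceptor and brings a six-membered aromatic ring of carbon only, yet the read-out stays at the bottom of its scale. Nothing at hand explains this outcome.

Since both compounds sit at the bottom of the scale, the step cannot show whether the two groups would differ in a setting where the core gave a measurable signal at the concentration tested. As far as these compounds go, it also remains open whether a primary amine, a carboxylic acid or a longer alkyl chain on the same aromatic carbon would leave this assay equally unmoved.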